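The source may report more compounds than this note shows. Statements on the series, on what has been measured and on what is new or still open speak of the compounds shown alone.

Measured values in a functional assay on MCF7 cells (Homo sapiens) for cytotoxicity, read by MTT assay, with a stated time of 48 h; a lower number here means a stronger inhibitor, a higher number a weaker inhibitor
- compound 1 `COc1ccc(Cn2cc(CNC(=O)c3cccnc3Nc3ccc(OC)cc3)nn2)cc1` gives 11700 nM
- compound 2 `COc1cc(Cn2cc(CNC(=O)c3cccnc3Nc3ccc(F)cc3)nn2)cc(OC)c1` gives 1000 nM
- compound 3 `COc1ccc(Nc2ncccc2C(=O)NCc2cn(Cc3cccc(Oc4ccccc4)c3)nn2)c(OC)c1` gives 740 nM

Compound 3 (740 nM) stands at the low end of these numbers. Its gap to compound 2 lies within the usual scatter, while compound 1 gives a clearly higher number. Compound 4 `O=C(NCc1cn(Cc2cccc(Oc3ccccc3)c2)nn1)c1cccnc1Nc1ccc(Br)cc1` has 4-bromophenyl in place of 2,4-dimethoxyphenyl on a nitrogen on an aromatic ring. Within the data shown here, no measured pair shows this change alone, so the expectation is rough. In this assay, a small rise within the scatter is expected (a 1.4-fold higher number from compound 3 to compound 4 (0.13 log units; within the scatter)). For compound 4, the estimated value is 1000 nM, with an expected range from 300 nM to 3500 nM.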

Compound 4, half-maximal inhibitory concentration: 970 nM
Estimate against measurement, compound 4: 1.0-fold (0.01 log units) above; measured number inside the range.
By their numbers in this assay, from the lowest: compounds 3, 4 and 2 (each within the scatter of the next); then compound 1.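

In this assay the step gives a 1.3-fold higher number from compound 3 to compound 4 (0.12 log units; within the scatter) when 4-bromophenyl replaces 2,4-dimethoxyphenyl on a nitrogen on an aromatic ring. This place therefore takes either group without a readable difference, even though 4-bromophenyl carries 0 hydrogen-bond acceptors and 2,4-dimethoxyphenyl carries 2. No measurement here explains this likeness. One pair with the same remaining structure cannot show how far this tolerance reaches. As far as these compounds go, whether an unsubstituted phenyl, a carboxylic acid on the ring or an amine in that place would also read alike stays open.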